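The source may report more compounds than this note shows. Statements on the series, on what has been measured and on what is new or still open speak of the compounds shown alone.

Measured so far:
Compound 1, `Cc1cccc(/C(N)=N/NC(=S)N2CCCCC2)n1`, gives 83.5% in a functional assay on HeLa cells (Homo sapiens) for cytotoxicity, read by MTT assay, with a stated time of 72 h, tested at 10 uM; a higher number here means more inhibition of growth at the concentration tested, a lower number less inhibition of growth.
Compound 2, `Cc1cccc(/C(N)=N/NC(=S)N2CCCC2)n1`, gives 79.2%.
Compound 3, `Cc1ccnc(/C(N)=N/NC(=S)N2CCCCC2)c1`, gives 62.1%.

Compound 1 and compound 2 differ by a single change, (pyrrolidin-1-yl in place of piperidin-1-yl on a thiocarbonyl carbon), and that change brought a number 4.3 percentage points lower from compound 1 to compound 2 (within the scatter). Compound 3 is built from the same atoms as compound 1, joined differently; the difference between the two cores is not broken down here. Compound 3 stands lowest of the three, with its steps to compound 1 and compound 2 beyond the scatter. Compound 4, `Cc1ccnc(/C(N)=N/NC(=S)N2CCCC2)c1`, is not yet measured and carries the same change made from compound 3: pyrrolidin-1-yl in place of piperidin-1-yl on a thiocarbonyl carbon. Because the earlier step of a number 4.3 percentage points lower from compound 1 to compound 2 (within the scatter) stayed within the scatter, the step from compound 3 to compound 4 is expected to be small as well, estimated at a number 4.1 percentage points lower from compound 3 to compound 4 (within the scatter). Compound 4 is therefore estimated at 58%, expected between 45% and 70%.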

Compound 4, percent growth inhibition at one concentration: 67%
Beside the measured number, compound 4's estimate is 9 percentage points below it; measured number inside the range.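

In this assay, putting pyrrolidin-1-yl in place of piperidin-1-yl on the thiocarbonyl carbon gave a number 4.9 percentage points higher from compound 3 to compound 4 (within the scatter) on this second core, and the two steps agree as closely as such measurements can show: the same change on two cores in this assay, a number 4.3 percentage points lower (within the scatter) from compound 1 to compound 2 and a number 4.9 percentage points higher (within the scatter) from compound 3 to compound 4, 9.2 percentage points apart, within the scatter of two such steps. So in these two pairs, the change carries from one core to the other as a small step. This does not show that the change truly raises or lowers growth inhibition on either core, and two cores cannot establish a rule for the whole series.

The compounds shown leave open what other groups on the thiocarbonyl carbon would give, such as morpholin-4-yl or an open-chain diethylamino group. As far as these compounds go, whether the step would stay small on a third core also remains open.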